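Adding hydroxy to the four-membered ring of compound 3

The source may report more compounds than this note shows. Statements on the series, on what has been measured and on what is new or still open speak of the compounds shown alone.

In an ADME assay on MDCKII-LE cells (Canis lupus familiaris) for permeability (on this read-out lower numbers stand for lower permeability and higher numbers for higher permeability), compound 1 (`Cc1cnc(NC(=O)c2cc(Oc3ccc(C#N)cc3)c3cc(C)oc3c2)cn1`) gives 1.5 10^-6 cm/s and compound 2 (`CNC(=O)c1cnc(Oc2cc(C(=O)Nc3cnc(C)cn3)cc3oc(C)cc23)cn1`) gives 20.9 10^-6 cm/s. Going by the values given here, the only measured step is a 14-fold higher number from compound 1 to compound 2 (1.14 log units; beyond the scatter), with 5-(methylcarbamoyl)pyrazin-2-yl in place of 4-cyanophenyl on an oxygen on an aromatic ring. Compound 3 (`Cc1cc2c(Oc3cnc(C(=O)N4CC(C)C4)cn3)cc(C(=O)Nc3cnccn3)cc2o1`) gives 14.9 10^-6 cm/s. That value lies within the scatter of compound 2 at 20.9 10^-6 cm/s and well above compound 1 at 1.5 10^-6 cm/s.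

Compound 4 (`Cc1cc2c(Oc3cnc(C(=O)N4CC(C)(O)C4)cn3)cc(C(=O)Nc3cnccn3)cc2o1`) carries hydroxy in place of hydrogen on a saturated ring carbon of compound 3: hydroxy in place of hydrogen on a saturated ring carbon. Among the compounds with values here, no measured step changes this ring, so the large step above offers only indirect guidance, and no measured pair tests this change. A moderate move to a lower number is nevertheless expected, resting on the structural change alone and smaller than that large step. The estimated step is a 2.1-fold lower number from compound 3 to compound 4 (0.33 log units; beyond the scatter). For compound 4 the expected value in this assay is 7 10^-6 cm/s, with an estimated range of 3 10^-6 cm/s to 14 10^-6 cm/s.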

Compound 4, apparent permeability: 9 10^-6 cm/s
Estimate against measurement, compound 4: 1.3-fold (0.11 log units) below; the range from low to high includes it.
By their numbers in this assay, from the lowest: compound 1; then compounds 4, 3 and 2 (each within the scatter of the next, the first and the last beyond it).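

In this assay, the change from 3-methylazetidin-1-yl to 3-hydroxy-3-methylazetidin-1-yl gives a 1.7-fold lower number from compound 3 to compound 4 (0.22 log units; within the scatter), so this read-out does not separate the two compounds. Going by these compounds alone, this is the first measured change on the four-membered ring, as the earlier step concerned the group on the oxygen, and it shows that a hydroxy, with its hydrogen-bond donor and acceptor, can stand on this saturated ring carbon without a step beyond the scatter. Nothing available explains this result.

The compounds shown leave open whether an amine, a carboxylic acid or a methoxy group on the same carbon would stay as close to compound 3. They also leave open whether hydroxy would behave alike with the 5-methylpyrazine amide of compound 2 in place of the unsubstituted one.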